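From tert-butoxy to 1-methyl-1-(trifluoromethyl)ethoxy

A few compounds are considered here, and "the series" means these few. Any claim that something is new, unique, unknown or untested is made for them only; others in the source may bear on it.

Of the compounds shown here, three have been measured so far in an ADME assay on microsomes from liver (Homo sapiens) for metabolic stability, read by LC-MS, using NADPH, with a stated time of 45 min; a lower number here means that the compound disappears faster, a higher number that the compound lasts longer. Compound 1 (`CC[C@@H]1CCCC/C=C\[C@@H]2C[C@@]2(C(=O)NS(=O)(=O)C2CC2)NC(=O)[C@@H]2C[C@@H](Oc3ncc(OC)c4ccc(Cl)cc34)CN2C(=O)[C@H]1NC(=O)OC(C)(C)C(F)(F)F`) gives 0.8 h, compound 2 (`COc1cnc(O[C@@H]2C[C@H]3C(=O)N[C@]4(C(=O)NS(=O)(=O)C5CC5)C[C@H]4/C=C\CC[C@@H](C)C[C@@H](C)[C@H](NC(=O)OC(C)(C)C(F)(F)F)C(=O)N3C2)c2ccccc12`) gives 0.198 h, and compound 3 (`CC[C@@H]1C[C@H](C)CC/C=C\[C@@H]2C[C@@]2(C(=O)NS(=O)(=O)C2CC2)NC(=O)[C@@H]2C[C@@H](Oc3ncc(OC)c4ccccc34)CN2C(=O)[C@H]1NC(=O)OC(C)(C)C`) gives 0.143 h. Compound 3 therefore stands within the scatter of compound 2, while compound 1 has a higher number, beyond the scatter.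

Compound 4 (`CC[C@@H]1C[C@H](C)CC/C=C\[C@@H]2C[C@@]2(C(=O)NS(=O)(=O)C2CC2)NC(=O)[C@@H]2C[C@@H](Oc3ncc(OC)c4ccccc34)CN2C(=O)[C@H]1NC(=O)OC(C)(C)C(F)(F)F`) has not yet been measured. It departs from compound 3 in one place: trifluoromethyl in place of methyl on a saturated chain carbon bound to an oxygen next to a carbonyl group and two saturated chain carbons. This puts trifluoromethyl in place of methyl on a saturated chain carbon bound to an oxygen next to a carbonyl group and two saturated chain carbons, turning tert-butoxy into 1-methyl-1-(trifluoromethyl)ethoxy.

Going by the values given here, compound 1 and compound 2 both carry that group, but each also differs from compound 3 elsewhere, so no measured pair isolates the change. The expectation leans on compound 2 at 0.198 h, with only slight weight on compound 1 at 0.8 h. The expected change is a small rise within the scatter, a 1.7-fold higher number from compound 3 to compound 4 (0.22 log units; within the scatter). Compound 4 is estimated at 0.24 h, with an expected range from 0.12 h to 0.55 h.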

Compound 4, half-life: 0.628 h
For compound 4 the middle estimate is 2.6-fold (0.42 log units) below the measured one; measured number outside the range, above it.
By their numbers in this assay, from the lowest: compounds 3 and 2 (each within the scatter of the next); then compounds 4 and 1 (each within the scatter of the next).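

In this assay, the swap of methyl for trifluoromethyl on a saturated chain carbon bound to an oxygen next to a carbonyl group and two saturated chain carbons can now be read on its own, and it gives a 4.4-fold higher number from compound 3 to compound 4 (0.64 log units; beyond the scatter) in a single step. Compound 4 also opens a second single-place comparison: methyl in place of hydrogen on a saturated chain carbon bound to a saturated ring carbon gives a 3.2-fold higher number from compound 2 to compound 4 (0.50 log units; beyond the scatter) as a further step beyond the scatter. Nothing at hand accounts for either step.

The compounds shown leave open whether the trifluoromethyl swap would act alike on the core of compound 1, which has no partner carrying tert-butoxy. They also leave open what difluoromethyl or pentafluoroethyl would give in place of methyl at this position.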